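Lengthening the hydroxamate chain on a propargylamine aniline

The compounds below may be only part of what the source reports. "The series", "measured", "known", "first", "only" and "open" are said of these compounds alone.

Measured so far in a functional assay on PC-3 cells (Homo sapiens) for inhibition, read by MTT assay, with a stated time of 48 h; on this read-out lower numbers stand for stronger inhibition of growth and higher numbers for weaker inhibition of growth:
compound 1, `C#CCN(C)Cc1ccc(NC(=O)CCCCC(=O)NO)cc1`: > 10000 nM, an assay limit rather than a number
compound 2, `C#CCN(C)Cc1ccc(NC(=O)CCCCCC(=O)NO)cc1`: > 10000 nM, again an assay limit rather than a number
compound 3, `C#CCN(C)Cc1ccc(NC(=O)CCCCCCCC(=O)NO)cc1`: 7160 nM

Compound 1 and compound 2 differ by one change, ((hydroxycarbamoyl)methyl in place of hydroxycarbamoyl on a saturated chain carbon, four bonds along the chain from a carbonyl carbon), and the step between them is a step that the two limits leave unreadable from compound 1 to compound 2, because both sit at the limit of > 10000 nM in this assay, at which 2 of the 3 values shown sit. Compound 3 differs from compound 1 by 3-(hydroxycarbamoyl)propyl in place of hydroxycarbamoyl on a saturated chain carbon, four bonds along the chain from a carbonyl carbon, and the steps to it are an at least 1.3-fold lower number from compound 1 to compound 3 (0.14 log units; that floor lies within the scatter) and an at least 1.3-fold lower number from compound 2 to compound 3 (0.14 log units; that floor lies within the scatter). Compound 4, `C#CCN(C)Cc1ccc(NC(=O)CCCCCCCCC(=O)NO)cc1`, has not been measured. It differs from compound 3 by (hydroxycarbamoyl)methyl in place of hydroxycarbamoyl on a saturated chain carbon, seven bonds along the chain from a carbonyl carbon, the same kind of change as that from compound 1 to compound 2, but here on a saturated chain carbon seven bonds along the chain from a carbonyl carbon rather than four. For the measured compounds named here, since compound 3 is the only measured number, and the step from compound 1 to compound 2 is unreadable, the expected step from compound 3 to compound 4 in this assay is estimated as a 1.6-fold lower number from compound 3 to compound 4 (0.20 log units; within the scatter), with wide uncertainty. Compound 4 is therefore expected to give about 4500 nM, likely between 1500 nM and 12000 nM.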

Compound 4, concentration for 50% growth inhibition: 4260 nM
Compound 4: the middle estimate sits 1.1-fold (0.02 log units) above what was measured; measured number inside the range.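

In this assay the newest step is a 1.7-fold lower number from compound 3 to compound 4 (0.23 log units; within the scatter), and the steps from the two shorter chains are an at least 2.3-fold lower number from compound 2 to compound 4 (0.37 log units; beyond the scatter) and an at least 2.3-fold lower number from compound 1 to compound 4 (0.37 log units; beyond the scatter). The same change, 3-(hydroxycarbamoyl)propyl in place of hydroxycarbamoyl, can therefore be set side by side on two cores: the same change on two cores in this assay, an at least 1.3-fold lower number (0.14 log units; that floor lies within the scatter) from compound 1 to compound 3 and an at least 2.3-fold lower number (0.37 log units; beyond the scatter) from compound 2 to compound 4; the limit leaves it open whether they differ. This shows a lower number beyond the scatter for the change on the core of compound 2, but it does not show that the size of the step carries over to the core of compound 1, as compound 1 and compound 2 both start from an assay limit rather than a number: the limit of > 10000 nM in this assay, at which 2 of the 4 values shown sit.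

The compounds shown leave open whether a longer chain would lower the number further or raise it again. They also leave open what a carboxylic acid in place of the hydroxycarbamoyl group would give on this same core.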